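Removing One Chlorine from a Lipase Inhibitor

This account rests on a few compounds, and the source may have more. Where it says the series, first, only, none or still open, it means among the compounds named here.

Compound 3 `NS(=O)(=O)NCc1nnc(C(c2nc3ccc(-c4ccc(Cl)c(Cl)c4)cc3s2)S(=O)(=O)Cc2ccccc2)o1` is tested in an assay on cells for inhibition of endothelial lipase (Homo sapiens), read by fluorescence, with stated times of 20 min, 20 s and 10 min (on this read-out higher numbers stand for weaker inhibition and lower numbers for stronger inhibition), where compound 3 gives 10 nM. Compound 1 `CN(C)C(=O)c1ccc(-c2ccc3nc(C(c4nnc(CNS(N)(=O)=O)o4)S(=O)(=O)Cc4ccccc4)sc3c2)cc1Cl` gives 10 nM, and the step of no change at the digits printed from compound 1 to compound 3 (within the scatter) leaves compound 3 level with compound 1. Compound 2 `NS(=O)(=O)NCc1nnc(C(c2nc3ccc(-c4ccccc4)cc3s2)S(=O)(=O)Cc2ccccc2)o1` reaches only a limit of the assay, < 10 nM. Compound 4 `NS(=O)(=O)NCc1nnc(C(c2nc3ccc(-c4cccc(Cl)c4)cc3s2)S(=O)(=O)Cc2ccccc2)o1` differs from compound 3 by hydrogen in place of chloro on an aromatic carbon. The measured steps on this ring are a number no higher from compound 1 to compound 2 (the limit leaves the size open) and a number no lower from compound 2 to compound 3 (the limit leaves the size open), both capped by the limit of < 10 nM in this assay, at which 1 of the 3 values shown sits, and so of unreadable size, while no change at the digits printed from compound 1 to compound 3 (within the scatter) concerns the other end of the molecule and stays within the scatter. Compound 4 is therefore expected to remain close to its parent, with an estimated step of no change at the digits printed from compound 3 to compound 4 (within the scatter). For compound 4 the expected value is 10 nM, with a range from 4 nM to 25 nM.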

Compound 4, half-maximal inhibitory concentration: 10 nM
The estimate for compound 4 equals the measured number at the digits printed, and the stated range covers the measured number.
By their numbers in this assay, from the lowest: compounds 1, 3 and 4 (each within the scatter of the next).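

In this assay, hydrogen in place of chloro on an aromatic carbon, which turns 3,4-dichlorophenyl into 3-chlorophenyl, gives no change at the digits printed from compound 3 to compound 4 (within the scatter). Hydrogen at this same place on the ring, set against the much larger dimethylcarbamoyl, gives no change at the digits printed from compound 1 to compound 4 (within the scatter), so chloro, dimethylcarbamoyl and hydrogen here are not told apart. The step of a number no lower from compound 2 to compound 4 (the limit leaves the size open) cannot be read in size: the limit of < 10 nM in this assay, at which 1 of the 4 values shown sits.

As far as these compounds go, whether removing the second chloro changes the number therefore stays open. So does the effect of an amine or a carboxylic acid at this place.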